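Notes on bromo replacing (oxiran-2-yl)methoxy

This account rests on a few compounds, and the source may have more. Where it says the series, first, only, none or still open, it means among the compounds named here.

Measured in a functional assay on SW-620 cells (Homo sapiens) for cytotoxicity; on this read-out lower numbers stand for stronger inhibition of growth and higher numbers for weaker inhibition of growth:
- compound 1 `CSc1ccc(C2=C(c3ccc(O)c(O)c3)C(=O)N3CCCC3C2)cc1`: 50000 nM
- compound 2 `COc1ccc(C2=C(c3ccc(SC)cc3)CC3CCCN3C2=O)cc1`: 3000 nM
- compound 3 `CSc1ccc(C2=C(c3ccc(OCC4CO4)cc3)C(=O)N3CCCC3C2)cc1`: 90 nM

Compound 3 has the lowest number of the three, and its gaps to both others lie beyond the scatter. Compound 4 `CSc1ccc(C2=C(c3ccc(Br)cc3)C(=O)N3CCCC3C2)cc1` changes it as follows: bromo in place of (oxiran-2-yl)methoxy on an aromatic carbon. Two measured steps changed the group at this place, and both were large: a 17-fold lower number from compound 1 to compound 2 (1.22 log units; beyond the scatter) and a 33-fold lower number from compound 2 to compound 3 (1.52 log units; beyond the scatter). For the measured compounds named here, no bromo compound has been measured, so the size is uncertain. The second step suggests that losing the oxiran-2-yl group will raise the number in this assay by a large step. The expected step is a 22-fold higher number from compound 3 to compound 4 (1.35 log units; beyond the scatter). For compound 4 the estimated value is 2000 nM, with an expected range of 300 nM to 15000 nM.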

Compound 4, concentration for 50% growth inhibition: 7000 nM
Compound 4: the middle estimate sits 3.5-fold (0.54 log units) below what was measured; low and high end bracket the measured number.
By their numbers in this assay, from the lowest: compound 3; then compound 2; then compound 4; then compound 1.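

In this assay, bromo on this aromatic carbon gives a 78-fold higher number from compound 3 to compound 4 (1.89 log units; beyond the scatter), so the low number of compound 3 is not kept by a simple halogen at this place. The change is only modest in the other two comparisons: a 2.3-fold higher number from compound 2 to compound 4 (0.37 log units; beyond the scatter) for bromo in place of methoxy, and a 7.1-fold lower number from compound 1 to compound 4 (0.85 log units; beyond the scatter) for 4-bromophenyl in place of 3,4-dihydroxyphenyl. Nothing available explains these differences.

Open, from the compounds shown here alone, is whether the oxiran-2-yl ring itself is needed, or whether a propoxy chain would hold the number of compound 3 at this place. Going by these compounds, an amine-bearing chain here also remains open.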